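The source may hold more compounds than are shown below. What is called first, only, known or untested is meant among the compounds shown, and "the series" means these compounds.

The shared core of these compounds carries an amide whose nitrogen substituent varies. Compound 1 `C=CC1=C(C(=O)NCc2ccc(C)cc2)C(c2ccc(F)cc2)OC1` bears a 4-methylbenzyl group on the amide nitrogen, and in a functional assay on QGY7701 cells (Homo sapiens) for cytotoxicity, read by MTT assay, with a stated time of 24 h (on this read-out lower numbers stand for stronger inhibition and higher numbers for weaker inhibition), compound 1 gives 62100 nM. Compound 3 `C=CC1=C(C(=O)NC(C)(C)C)C(c2ccc(F)cc2)OC1` carries tert-butyl on that nitrogen. In this assay compound 3 reaches only a limit of the assay, > 100000 nM. The step of an at least 1.6-fold higher number from compound 1 to compound 3 (0.20 log units; that floor lies within the scatter). Compound 2 `C=CC1=C(C(=O)NC(C)(C)C)C(c2ccc(OC)cc2)OC1` keeps the tert-butyl amide and has methoxy on the aromatic carbon where compound 3 has fluoro. In this assay compound 2 likewise returns a limit rather than a number, > 100000 nM. The step that the two limits leave unreadable from compound 2 to compound 3, since (the limit of > 100000 nM in this assay, at which 2 of the 3 values shown sit). So compound 2 stands at the limit, without a readable number.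

Compound 4 `C=CC1=C(C(=O)NC2CCCCC2)C(c2ccc(OC)cc2)OC1` differs from compound 2 by cyclohexyl in place of tert-butyl on an amide-type nitrogen. Among the measured compounds shown here, no measured step makes this exchange; the only step that alters the amide substituent, from compound 1 to compound 3, goes from 4-methylbenzyl to tert-butyl and ends at the limit, and the step from compound 2 to compound 3 cannot be read at all. Compound 4 is therefore expected to remain near the limit, with a step of a number no higher from compound 2 to compound 4 (the limit leaves the size open) that is not expected to go beyond the scatter. For compound 4 the estimate in this assay is 100000 nM, ranging from 40000 nM to 300000 nM.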

Compound 4, half-maximal inhibitory concentration: > 100000 nM
Compound 4: a limit, no number; the forecaster's own chance of this, stated with the estimate: 60%; the middle value lies on the limit itself.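

In this assay compound 4 returns a limit of the assay, > 100000 nM, rather than a number. No step from compound 2 to compound 4 can be read, because both stand at a limit: the limit of > 100000 nM in this assay, at which 3 of the 4 values shown sit.

The compounds shown leave open how cyclohexyl and tert-butyl on an amide-type nitrogen compare in this assay.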